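Aryl-methyl amine series: antiproliferative limits only

The source may hold more compounds than are shown below. What is called first, only, known or untested is meant among the compounds shown, and "the series" means these compounds.

Compound 1 `Cc1cccc(CNc2ncnc3c2ncn3[C@@H]2O[C@H](CO)[C@@H](O)[C@H]2O)c1`, in a functional assay on MCF cells (Homo sapiens) for antiproliferative activity, with a stated time of 72 h (a lower number here means a stronger inhibitor, a higher number a weaker inhibitor), compound 1 gives > 166000 nM, a limit of the assay.
Compound 2 `COc1cccc(CNc2ncnc3c2ncn3[C@@H]2O[C@H](CO)[C@@H](O)[C@H]2O)c1`, in this assay compound 2 gives > 166000 nM, again a limit.
Compound 3 `COc1cccc(CNc2ncnc3c2ncn3[C@@H]2O[C@H](CO)[C@@H](O)[C@H]2O)c1OC`, in this assay compound 3 gives > 166000 nM, also a limit.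

None of the three measured compounds returns a number: each sits at the limit of > 166000 nM in this assay, at which 3 of the 3 values shown sit. The steps between them, methoxy in place of methyl on an aromatic carbon a step that the two limits leave unreadable from compound 1 to compound 2, 2,3-dimethoxyphenyl in place of 3-methylphenyl on a saturated chain carbon bound to a nitrogen on an aromatic ring a step that the two limits leave unreadable from compound 1 to compound 3, and methoxy in place of hydrogen on an aromatic carbon a step that the two limits leave unreadable from compound 2 to compound 3, are therefore all of unreadable size. Compound 3 stands where the other two stand, at the limit.

Compound 4 `Cc1cccc(CNc2ncnc3c2ncn3[C@@H]2O[C@H](CO)[C@@H](O)[C@H]2O)c1O` differs from compound 3 by 2-hydroxy-3-methylphenyl in place of 2,3-dimethoxyphenyl on a saturated chain carbon bound to a nitrogen on an aromatic ring. The steps from compound 1 and compound 2 to compound 3 touch the same place, but both are unreadable, so no size of effect can be taken from them. The expectation is that compound 4 in this assay also remains at the limit; the estimated step is a step that the limit leaves unreadable from compound 3 to compound 4. Compound 4 is estimated at 250000 nM, with a range from 100000 nM to 800000 nM.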

Compound 4, half-maximal inhibitory concentration: 6900 nM
For compound 4 the middle estimate is 36-fold (1.56 log units) above the measured one; the measured number lies below the stated range.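

In this assay, for the compounds shown here, the aryl group on a saturated chain carbon bound to a nitrogen on an aromatic ring can move the read-out, and 2-hydroxy-3-methylphenyl is the first group here to bring a compound off the limit. The clearest comparison is the addition of a single hydroxy to the aryl group, an at least 24-fold lower number from compound 1 to compound 4 (1.38 log units; beyond the scatter), while the replacements of the methoxy-bearing aryl groups give an at least 24-fold lower number from compound 2 to compound 4 (1.38 log units; beyond the scatter) and an at least 24-fold lower number from compound 3 to compound 4 (1.38 log units; beyond the scatter). All three steps start from a limit, so they set minimum sizes only, and the steps among compound 1, compound 2 and compound 3 cannot be read: the limit of > 166000 nM in this assay, at which 3 of the 4 values shown sit.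

The compounds shown do not tell whether the hydroxy is enough on its own or works only with the methyl group of compound 4, as 2-hydroxyphenyl would show. They also leave open whether an amine or a carboxylic acid in place of the hydroxy would keep the compound off the limit in this assay.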